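The source may hold more compounds than are shown below. What is called first, only, known or untested is meant among the compounds shown, and "the series" means these compounds.

Measured so far in a functional assay on COR-L23 cells (Homo sapiens) for antiproliferative activity, read by CellTiter-Glo, with a stated time of 4 days; a higher number here means a weaker inhibitor, a lower number a stronger inhibitor:

compound 1 `O=C(NCc1cccnc1)Nc1ccc(CNC(=O)c2ccc(CN3CCNCC3)cc2)cc1` gives 137 nM
compound 2 `CCC(=O)N[C@@H](C)c1ccc(NC(=O)[C@H]2C[C@@H]2c2cccnc2)cc1` gives 22 nM

For the measured compounds named here, only two numbers are available here, and compound 2 holds the lower one. With 22 nM, compound 2 is the stronger inhibitor of the pair, and its gap to compound 1 lies beyond the usual scatter of repeated measurements. The two compounds differ in much of their structure, which leaves this gap with little to say about any single group.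

The next compound, compound 3 `COCC(=O)N[C@@H](C)c1ccc(NC(=O)[C@H]2C[C@@H]2c2cccnc2)cc1`, keeps the shared core of compound 2 and changes it in one place: methoxy in place of methyl on a saturated chain carbon bound to a carbonyl carbon. In words, methoxy stands in place of methyl on a saturated chain carbon bound to a carbonyl carbon.

Going by the values given here, no pair of measured compounds shows this change, and the expectation is therefore a cautious one. It starts from compound 2 at 22 nM and assumes that such a small edit moves the number only modestly, perhaps slightly upward. The expected size of the move is a 1.4-fold higher number from compound 2 to compound 3 (0.13 log units; within the scatter), which may not exceed the scatter. For compound 3 the estimated value is 30 nM, with an expected range from 11 nM to 85 nM.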

Compound 3, half-maximal inhibitory concentration: 111 nM
Estimate against measurement, compound 3: 3.7-fold (0.57 log units) below; the measured number lies above the stated range.
By their numbers in this assay, from the lowest: compound 2; then compounds 3 and 1 (each within the scatter of the next).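

In this assay, this end of the propanoyl group proves sensitive to a small edit: methoxy in place of methyl on a saturated chain carbon bound to a carbonyl carbon gives a 5.0-fold higher number from compound 2 to compound 3 (0.70 log units; beyond the scatter). The rest of the molecule stays the same. This step can be tied to this one place, which the earlier comparison of two very different structures could not do. The change brings in an oxygen and a hydrogen-bond acceptor, yet no measured evidence here explains why the number rises.

From the compounds shown here alone, it remains open whether the step follows the oxygen itself or simply the longer chain, since a single pair cannot separate the two. An ethyl group at this place, which would give a chain of similar length without the oxygen, would help to tell them apart, while a hydroxyl group or an amine would show how other groups at the same carbon compare.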